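A few compounds are considered here, and "the series" means these few. Any claim that something is new, unique, unknown or untested is made for them only; others in the source may bear on it.

Measured in a toxicity assay on HepG2 2.2.15 cells (Homo sapiens) for cytotoxicity, read by CellTiter-Glo; a higher number here means that more compound is tolerated, a lower number that less compound is tolerated:
- compound 1 `O=C1CC(c2cnc(C(F)(F)F)s2)CN1c1cnn2c1CN(C(=O)Nc1cc(F)c(F)c(F)c1)C(C1CC1)C2`: 38500 nM
- compound 2 `O=C1CC(C(F)(F)F)CN1c1cnn2c1CN(C(=O)Nc1cc(F)c(F)c(F)c1)C(C1CC1)C2`: 115000 nM
- compound 3 `O=C1CC(c2ccc(F)cc2)CN1c1cnn2c1CN(C(=O)Nc1cc(F)c(F)c(F)c1)C(C1CC1)C2`: 32100 nM

Compound 3 shares the low end of these numbers with compound 1, and compound 2 stands clear of both. Compound 4 `O=C1CC(c2ncco2)CN1c1cnn2c1CN(C(=O)Nc1cc(F)c(F)c(F)c1)C(C1CC1)C2` carries 1,3-oxazol-2-yl in place of 4-fluorophenyl on a saturated ring carbon. Among the compounds with values here, the closest precedent, an exchange of one aromatic ring for another, is a 1.2-fold lower number from compound 1 to compound 3 (0.08 log units; within the scatter). Trifluoromethyl, which is not a ring, gives the larger 3.6-fold lower number from compound 2 to compound 3 (0.55 log units; beyond the scatter) and a 3.0-fold higher number from compound 1 to compound 2 (0.48 log units; beyond the scatter), so it bears on compound 4 only loosely. A modest rise in this assay at most therefore seems likely. The expected change is a 1.7-fold higher number from compound 3 to compound 4 (0.23 log units; within the scatter). For compound 4 the estimated value is 55000 nM, with an expected range from 28000 nM to 110000 nM.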

Compound 4, half-maximal cytotoxic concentration: > 200000 nM
Compound 4: no number, only a limit (the forecaster's own chance of this, stated with the estimate: 15%); middle value at least 3.6-fold (0.56 log units) from the limit.
By their numbers in this assay, from the lowest: compounds 3 and 1 (each within the scatter of the next); then compound 2. At a limit, above all of these: compound 4.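

In this assay compound 4 gives no number, only a limit: the limit of > 200000 nM in this assay, at which 1 of the 4 values shown sits.

At this saturated ring carbon, one aromatic ring in place of another can thus move the number beyond the scatter, with an at least 6.2-fold higher number from compound 3 to compound 4 (0.79 log units; beyond the scatter) and an at least 5.1-fold higher number from compound 1 to compound 4 (0.71 log units; beyond the scatter), whereas the exchange between compound 1 and compound 3 did not. Against trifluoromethyl there is an at least 1.7-fold higher number from compound 2 to compound 4 (0.24 log units; that floor lies within the scatter), so this floor does not separate the two.

The compounds shown leave open how far compound 4 lies past its limit. They also do not tell whether the hetero atoms or the five-membered ring carry the step, which an unsubstituted phenyl or an amine at this carbon would bear on.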